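Weak antiproliferative trisubstituted sugar ethers: next step

The source may report more compounds than this note shows. Statements on the series, on what has been measured and on what is new or still open speak of the compounds shown alone.

Measured so far:
compound 1 `COc1cc(C2=NOC(CO[C@@H]3O[C@H](CSc4ncn[nH]4)[C@H]4OC5(CCCC5)O[C@@H]34)C2)cc(OC)c1OC` gives 43000 nM
compound 2 `CC1(C)O[C@H]2[C@H](OCc3noc(-c4ccc([N+](=O)[O-])cc4)n3)O[C@H](CO)[C@H]2O1` gives 99000 nM

Both numbers come from a functional assay on HBL-100 cells (Homo sapiens) for antiproliferative activity, read by sulforhodamine B assay, with a stated time of 48 h; a lower number here means a stronger inhibitor of growth, a higher number a weaker inhibitor of growth. Compound 2 stands at the higher of the two values, so it is the weaker growth inhibitor of the pair; the gap to compound 1 lies beyond the usual scatter. Among the measured compounds shown here, no single-point step between measured compounds is available, so the two values say only that compound 2 is the weaker of the two and nothing about why.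

The next compound, compound 3 `CC1(C)O[C@H]2[C@H](OCc3noc(-c4ccc([N+](=O)[O-])cc4)n3)O[C@H](CSc3nnc(N)s3)[C@H]2O1`, follows from compound 2 by one change: (5-amino-1,3,4-thiadiazol-2-yl)sulfanyl in place of hydroxy on a saturated chain carbon bound to a saturated ring carbon. The change keeps the rest of compound 2 intact and places a larger, ring-bearing group on the saturated chain carbon bound to a saturated ring carbon.

For the measured compounds named here, with no measured step of this kind, the expected size of the step is modest, and the direction is taken as a lower number, that is a somewhat stronger inhibitor, but not with confidence beyond the scatter. Compound 3 is therefore estimated at 50000 nM in this assay, with a range from 15000 nM to 150000 nM, an expected step of a 2.0-fold lower number from compound 2 to compound 3 (0.30 log units; within the scatter).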

Compound 3, concentration for 50% growth inhibition: > 100000 nM
Compound 3: no number, only a limit; the forecaster's own chance of this, stated with the estimate: 25%; middle value at least 2.0-fold (0.30 log units) from the limit.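

Exchanging hydroxy for (5-amino-1,3,4-thiadiazol-2-yl)sulfanyl on a saturated chain carbon bound to a saturated ring carbon gives, in this assay, a number no lower from compound 2 to compound 3 (the limit leaves the size open). Compound 3 carries a limit and not a number, > 100000 nM, and this first single-point reading at this position shows that the larger, ring-bearing group brings no gain in growth inhibition over hydroxy. How far the change moves the value cannot be read, and the comparison ends at the limit of the assay: the limit of > 100000 nM in this assay, at which 1 of the 3 values shown sits.

Open, from the compounds shown here alone, is whether a small group on the same chain carbon, such as an amine or a methoxy group, would hold or lower the number while the rest of compound 2 stays unchanged. Also open, going by these compounds, is whether a nitrile in place of the nitro group would bring compound 3 to a readable number in this assay, which would give this exchange a size.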